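Chlorine added to the aryl ring of compound 1

This account rests on a few compounds, and the source may have more. Where it says the series, first, only, none or still open, it means among the compounds named here.

Measured compounds:
- compound 1, `N#CC1=C(N)Oc2c(c3nc4ccccc4nc3c3ccccc23)C12C(=O)N(Cc1cnnn1-c1ccc(F)cc1)c1ccccc12`: > 50000 nM
- compound 2, `N#CC1=C(N)Oc2c(c3nc4ccccc4nc3c3ccccc23)C12C(=O)N(Cc1cnnn1-c1cccc(S(N)(=O)=O)c1)c1ccccc12`: 21500 nM
- compound 3, `Cc1ccc(-n2nncc2CN2C(=O)C3(C(C#N)=C(N)Oc4c3c3nc5ccccc5nc3c3ccccc43)c3ccccc32)cc1Cl`: > 50000 nM

In a functional assay on HepG2 cells (Homo sapiens) for antiproliferative activity, read by MTT assay, with a stated time of 48 h (on this read-out lower numbers stand for stronger inhibition and higher numbers for weaker inhibition), compound 1 reaches only the assay limit, > 50000 nM, so no number is known for it. Compound 3 likewise sits at the limit, > 50000 nM. Within the data shown here, compound 2 gives a real number, 21500 nM, and the step of an at least 2.3-fold lower number from compound 1 to compound 2 (0.36 log units; beyond the scatter) is the one readable change among the three; the step of an at least 2.3-fold higher number from compound 2 to compound 3 (0.36 log units; beyond the scatter) goes the other way, and a step that the two limits leave unreadable from compound 1 to compound 3 stays hidden by the two limits (the limit of > 50000 nM in this assay, at which 2 of the 3 values shown sit).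

Compound 4, `N#CC1=C(N)Oc2c(c3nc4ccccc4nc3c3ccccc23)C12C(=O)N(Cc1cnnn1-c1ccc(F)c(Cl)c1)c1ccccc12`, is not yet measured. It differs from compound 1 by chloro in place of hydrogen on an aromatic carbon, which read one bond further out is 4-fluorophenyl to 3-chloro-4-fluorophenyl. Among the measured compounds shown here, no measured step adds a chloro on its own; compound 3, the only chlorine-bearing aryl, is also at the limit. The expected step is therefore a step that the limit leaves unreadable from compound 1 to compound 4, essentially none beyond the scatter. Compound 4 is estimated at 60000 nM, with a range of 25000 nM to 150000 nM, most likely again reported as a limit.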

Compound 4, half-maximal inhibitory concentration: > 50000 nM
Compound 4 was reported as a limit; the forecaster's own chance of this, stated with the estimate: 75%; the middle value does not contradict the limit.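

Putting chloro on the 4-fluorophenyl ring of compound 1 does not bring the compound into the range where a number can be read, so a single chlorine on this ring, alongside fluoro in compound 4 as alongside methyl in compound 3, has not given a readable value. Replacing 3-sulfamoylphenyl with 3-chloro-4-fluorophenyl gives an at least 2.3-fold higher number from compound 2 to compound 4 (0.36 log units; beyond the scatter), which leaves compound 2 as the only one of the four with a real number. The steps to compound 4 from compound 1 and from compound 3 cannot be read, since both ends of each are limits: the limit of > 50000 nM in this assay, at which 3 of the 4 values shown sit.

Going by these compounds, how far compounds 1, 3 and 4 lie beyond that limit stays unknown. On these data alone, it is also open whether another group on this phenyl ring, such as a carboxylic acid or an amine, would give a readable value as the sulfamoyl group does.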